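The source may report more compounds than this note shows. Statements on the series, on what has been measured and on what is new or still open speak of the compounds shown alone.

Working notes on the series.

Compound 3 `COc1ccc(/C=C/C(=O)Nc2cc(C(=O)c3cc(OC)c(OC)c(OC)c3)cc(OC)c2OC)cc1OC` carries the highest number of the three measured compounds in a functional assay on COLO 205 cells (Homo sapiens) for cytotoxicity, read by MTT assay, with a stated time of 72 h (on this read-out higher numbers stand for weaker inhibition and lower numbers for stronger inhibition), where compound 3 gives 5700 nM. Its nearest neighbour is compound 2 `COc1cc(C(=O)c2cc(OC)c(OC)c(OC)c2)cc(NC(=O)/C=C/c2cc(OC)c(OC)c(OC)c2)c1OC`, which in this assay gives 5300 nM; the furthest is compound 1 `COc1cccc(/C=C/C(=O)Nc2cc(C(=O)c3cc(OC)c(OC)c(OC)c3)ccc2OC)c1`, which in this assay gives 5100 nM. All three numbers sit within the scatter of one another, so no ordering among compounds 1, 2 and 3 can be read from them.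

The step to compound 4 `COc1cccc(/C=C/C(=O)Nc2cc(C(=O)c3cc(OC)c(OC)c(OC)c3)cc(OC)c2OC)c1` is hydrogen in place of methoxy on an aromatic carbon. Going by the values given here, one measured step bears on it: a 1.1-fold higher number from compound 2 to compound 3 (0.03 log units; within the scatter), which also removes a methoxy from the same aromatic ring, one bond further out reading 3,4,5-trimethoxyphenyl to 3,4-dimethoxyphenyl. That step stayed within the scatter. Compound 1, which likewise carries the 3-methoxyphenyl on the ethenyl arm, shows no number apart from the others. Nothing in the set therefore points to a change beyond the scatter in this assay on going to compound 4, and the expected step is a 1.0-fold lower number from compound 3 to compound 4 (0.02 log units; within the scatter).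

Compound 4 is accordingly estimated in this assay at 5500 nM, with a range from 2500 nM to 12000 nM.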

Compound 4, half-maximal inhibitory concentration: 10700 nM
Estimate against measurement, compound 4: 1.9-fold (0.29 log units) below; measured number inside the range.
By their numbers in this assay, from the lowest: compounds 1, 2, 3 and 4 (each within the scatter of the next, the first and the last beyond it).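

Taking 2-(3,4-dimethoxyphenyl)ethenyl to 2-(3-methoxyphenyl)ethenyl gives in this assay a 1.9-fold higher number from compound 3 to compound 4 (0.27 log units; within the scatter) and so does not by itself separate the two compounds, yet this change brings the first differences beyond the scatter in the series. Both are modest: a 2.0-fold higher number from compound 2 to compound 4 (0.31 log units; beyond the scatter) with 3-methoxyphenyl in place of 3,4,5-trimethoxyphenyl, and a 2.1-fold higher number from compound 1 to compound 4 (0.32 log units; beyond the scatter) with methoxy in place of hydrogen on an aromatic carbon. Hydrogen in place of methoxy can be compared at two places on two cores, and the two outcomes cannot yet be told apart: the same change on two cores in this assay, a 1.1-fold higher number (0.03 log units; within the scatter) from compound 2 to compound 3 and a 2.1-fold lower number (0.32 log units; beyond the scatter) from compound 4 to compound 1, 2.3-fold (0.35 log units) apart, within the scatter of two such steps.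

Only methoxy and hydrogen stand on the carbon ortho to a methoxy group and para to a large group, which leaves open how a hydroxy group, a chlorine or an amine there would read. Also open, going by these compounds, is whether the differences beyond the scatter hold in other cell lines, as every value shown comes from a single assay.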